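The source may report more compounds than this note shows. Statements on the series, on what has been measured and on what is new or still open speak of the compounds shown alone.

Working notes on a small series of four compounds sharing a spiro-fused lactam core carrying a butyl-linked basic amine, examined in a functional assay on the whole organism (strain Wistar) with Rattus norvegicus as the target, with a stated time of 5 min; on this read-out lower numbers stand for an effect already at smaller amounts and higher numbers for an effect only at larger amounts of compound.

Compound 1 `CCC1(CCCCN2CCN(c3ccc(Cl)c(Cl)c3)CC2)C(=O)Nc2ccccc21` gives in this assay only a limit, > 20 mg/kg, and no number. Compound 2 `CCC1(CCCCN2CCN(c3ccc(F)c(Cl)c3)CC2)C(=O)Nc2ccccc21` likewise gives only a limit, > 20 mg/kg. The change between them is fluoro in place of chloro on an aromatic carbon, and its effect is a step that the two limits leave unreadable from compound 1 to compound 2, since both ends are limits.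

Compound 3 `CCC1(CCCCN2CC=C(c3ccc(Cl)cc3)CC2)C(=O)Nc2ccccc21` carries a different core; the difference between the two cores is not broken down here. In this assay compound 3 also gives only a limit, > 20 mg/kg. For the measured compounds named here, the whole picture so far is the limit of > 20 mg/kg in this assay, at which 3 of the 3 values shown sit, so no step can be read.

Compound 4 `CCC1(CCCCN2CC=C(c3ccc(F)cc3)CC2)C(=O)Nc2ccccc21` is not yet measured; it differs from compound 3 by fluoro in place of chloro on an aromatic carbon. This is the same kind of change as that from compound 1 to compound 2, though there the place is ortho to a chloro group, whereas here it is not. With the earlier step unreadable and compound 3 at a limit, the expected step is a step that the limit leaves unreadable from compound 3 to compound 4, most likely again a limit. Compound 4 is estimated at 30 mg/kg, between 12 mg/kg and 100 mg/kg.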

Compound 4, minimum effective dose: 20 mg/kg
The estimate for compound 4 lay 1.5-fold (0.18 log units) above the measured number; the measured number falls inside the stated range.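

In this assay, for the compounds shown here, the change from 4-chlorophenyl to 4-fluorophenyl gives a number no higher from compound 3 to compound 4 (the limit leaves the size open), and this is the only fluoro-for-chloro step that ends on a number. On the core of compound 1 the same kind of change cannot be read, since both ends there are limits, so the two steps cannot be set side by side and nothing shows whether the change carries from one core to the other. The step on the core of compound 3 shows no more than a number reached at one end, and the series offers little to compare it with: the limit of > 20 mg/kg in this assay, at which 3 of the 4 values shown sit.

The compounds shown leave open what other groups at the same place on the aromatic ring, such as methoxy, nitrile or trifluoromethyl, would give in this assay. Also open, as far as these compounds go, is what a shorter or longer chain in place of the butyl linker would give on either core.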